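Swapping the group on the amide-type nitrogen of compound 3

This account rests on a few compounds, and the source may have more. Where it says the series, first, only, none or still open, it means among the compounds named here.

Of the compounds shown here, three of one shared core have been measured in a functional assay on cells for agonist activity at Bile acid receptor (Homo sapiens), read by a luciferase reporter; a lower number here means that less compound is needed, a higher number that more compound is needed for the effect. Compound 1 `O=C1NN(c2ccccc2)C(=O)/C1=C/c1cccc(OCc2cccc(F)c2)c1` gives 4790 nM, compound 2 `O=C1NN(c2ccccc2)C(=O)/C1=C/c1cccc(OCc2ccc(C(F)(F)F)cc2)c1` gives 2040 nM, and compound 3 `Cc1cccc(COc2cccc(/C=C3\C(=O)NN(c4ccccc4[N+](=O)[O-])C3=O)c2)c1` gives 5370 nM. The numbers of compound 3 and compound 1 lie within the scatter of each other, while compound 2 lies beyond the scatter from both. Among the compounds with values here, the single measured step, a 2.3-fold lower number from compound 1 to compound 2 (0.37 log units; beyond the scatter), alters the group on the saturated chain carbon bound to an oxygen on an aromatic ring. Compound 4 `Cc1cccc(COc2cccc(/C=C3\C(=O)NN(C(=O)c4ccncc4)C3=O)c2)c1` changes a different part of the molecule: (pyridin-4-yl)carbonyl in place of 2-nitrophenyl on an amide-type nitrogen in a ring. Within the data shown here, no measured step touches this position, so the data give no direction, and the step of a 1.1-fold lower number from compound 3 to compound 4 (0.03 log units; within the scatter) is expected to stay within the scatter. Compound 4 is estimated at 5000 nM, with a range from 1500 nM to 16000 nM.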

Compound 4, half-maximal effective concentration: 2400 nM
For compound 4 the middle estimate is 2.1-fold (0.32 log units) above the measured one; measured number inside the range.
By their numbers in this assay, from the lowest: compounds 2, 4, 1 and 3 (each within the scatter of the next, the first and the last beyond it).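

In this assay, the amide-type nitrogen in a ring proves to be a position that moves the number: (pyridin-4-yl)carbonyl in place of 2-nitrophenyl gives a 2.2-fold lower number from compound 3 to compound 4 (0.35 log units; beyond the scatter), a modest step. Within the data shown here, the earlier compounds all carried an aromatic ring directly on this nitrogen, so this is the first sign that a carbonyl-linked ring is tolerated here. Nothing available bears on the reason for this step. The change brings in the carbonyl and the ring nitrogen together, so the compounds shown leave open which of them matters. A benzoyl group on this nitrogen would separate the two.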